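A few compounds are considered here, and "the series" means these few. Any claim that something is new, unique, unknown or untested is made for them only; others in the source may bear on it.

In a functional assay on cells for antagonist activity at prostaglandin D2 receptor 2 (Homo sapiens), read by flow cytometry, with a stated time of 10 min (on this read-out higher numbers stand for weaker inhibition and lower numbers for stronger inhibition), compound 2 `COCCN(C)S(=O)(=O)c1ccc(C)c(C#Cc2cc(Cl)ccc2OCC(=O)O)c1` gives 77 nM, the lower of the two numbers recorded so far. Compound 1 `O=C(O)COc1ccc(Cl)cc1C#Cc1ccc(CO)cc1F` gives 680 nM in this assay, a gap that lies beyond the scatter. Compound 3 `Cc1ccc(S(=O)(=O)CC(C)C)cc1C#Cc1cc(Cl)ccc1OCC(=O)O` has not yet been measured in this assay. It differs from compound 2 only by isobutyl in place of (2-methoxyethyl)(methyl)amino on a sulfonyl sulfur, with the shared core left untouched. Among the measured compounds shown here, since no measured pair shows this kind of change, no step beyond the scatter is expected, and the estimated step from compound 2 to compound 3 reads a 1.0-fold higher number from compound 2 to compound 3 (0.02 log units; within the scatter). Compound 3 is therefore expected to give about 80 nM, within a range from 25 nM to 250 nM.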

Compound 3, half-maximal inhibitory concentration: 120 nM
Compound 3: middle estimate off by 1.5-fold (0.18 log units), on the low side, within the range that was stated.
By their numbers in this assay, from the lowest: compounds 2 and 3 (each within the scatter of the next); then compound 1.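

On a sulfonyl sulfur, isobutyl in place of (2-methoxyethyl)(methyl)amino gives a 1.6-fold higher number from compound 2 to compound 3 (0.19 log units; within the scatter) in this assay. This pair therefore shows that the position accepts an all-carbon group without the nitrogen and oxygen of the group that leaves, while the number stays within the scatter. Nothing measured here bears on why the two compounds read alike. The compounds shown leave open how a carboxylic acid, a primary amine or a chain longer than isobutyl would read on the same sulfur.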